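Fluoro for trifluoromethyl on the isopropoxy-bearing ring

This account rests on a few compounds, and the source may have more. Where it says the series, first, only, none or still open, it means among the compounds named here.

Measured compounds:
compound 1 `Cc1cc(CCC(=O)O)ccc1-c1noc(-c2ccc(OC(C)C)c(C(F)(F)F)c2)n1` — > 10000 nM, a limit of the assay
compound 2 `CCOc1ccc(-c2nc(-c3ccc(CCC(=O)O)cc3C)no2)cc1C(F)(F)F` — > 10000 nM, a limit of the assay

In a functional assay on CHO cells with sphingosine 1-phosphate receptor 2 (Homo sapiens) as the target, read by GTPgammaS binding (on this read-out lower numbers stand for an effect already at smaller amounts and higher numbers for an effect only at larger amounts of compound), compound 1 gives > 10000 nM, which is a limit and not a number. Compound 2 gives > 10000 nM, likewise a limit. Going by the values given here, the only measured step, a step that the two limits leave unreadable from compound 1 to compound 2, is therefore unreadable; (the limit of > 10000 nM in this assay, at which 2 of the 2 values shown sit). Compound 3 `Cc1cc(CCC(=O)O)ccc1-c1noc(-c2ccc(OC(C)C)c(F)c2)n1` differs from compound 1 by fluoro in place of trifluoromethyl on an aromatic carbon. Among the compounds with values here, no measured step covers this change. Compound 3 is expected to stay near the limit, a step that the limit leaves unreadable from compound 1 to compound 3. Compound 3 is estimated at 15000 nM, range 4000 nM to 50000 nM.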

Compound 3, half-maximal effective concentration: > 10000 nM
Compound 3: only a limit was reported; the forecaster's own chance of this, stated with the estimate: 80%; the middle value lies beyond the limit too.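

Compound 3 gives > 10000 nM, a limit and not a number, so the step from compound 1 to compound 3 cannot be read: the limit of > 10000 nM in this assay, at which 3 of the 3 values shown sit.

The compounds shown leave open whether fluoro or trifluoromethyl on this ring makes any difference to the read-out.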